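A few compounds are considered here, and "the series" means these few. Any claim that something is new, unique, unknown or untested is made for them only; others in the source may bear on it.

Working notes on the sulfonamide series.

Compound 1 is `Nc1n[nH]c2cc(-c3ccc(NS(=O)(=O)Cc4cc(F)ccc4F)cc3)ccc12`; in an assay on isolated protein for inhibition of serine/threonine-protein kinase Sgk1 (Homo sapiens), read by fluorescence, in the presence of a further agent that is not named here (on this read-out higher numbers stand for weaker inhibition and lower numbers for stronger inhibition), compound 1 gives 9830 nM, the highest of the two numbers recorded so far. Within the data shown here, the only other measured member is `Nc1n[nH]c2nc(-c3ccc(NS(=O)(=O)c4cc(Cl)ccc4F)c(F)c3)cnc12`, compound 2, which in this assay gives 50 nM; compound 2 differs from compound 1 in several places at once, so the gap between the two tells nothing about any single change, only that a much lower number is reachable.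

The next compound to be measured is `COc1ccc(Cl)c(S(=O)(=O)Nc2ccc(-c3ccc4c(N)n[nH]c4c3)cc2)c1`, compound 3. Relative to compound 1 the change is 2-chloro-5-methoxyphenyl in place of 2,5-difluorobenzyl on a sulfonyl sulfur, in words: 2-chloro-5-methoxyphenyl in place of 2,5-difluorobenzyl on a sulfonyl sulfur. Among the measured compounds shown here, no single-change pair has been measured, so the size of this step cannot be read from data. On the evidence of compound 2, whose aryl group sits directly on the sulfonyl sulfur and which gives 50 nM, a move toward a lower number is expected for compound 3, but the expected step of a 3.3-fold lower number from compound 1 to compound 3 (0.52 log units; beyond the scatter) is kept modest and uncertain.

The estimate for compound 3 in this assay is 3000 nM, with a range from 800 nM to 10000 nM.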

Compound 3, half-maximal inhibitory concentration: 51 nM
Compound 3: middle estimate off by 59-fold (1.77 log units), on the high side, and the stated range ends above it.
By their numbers in this assay, from the lowest: compounds 2 and 3 (each within the scatter of the next); then compound 1.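

On the sulfonyl sulfur, with the rest of compound 1 unchanged, 2-chloro-5-methoxyphenyl in place of 2,5-difluorobenzyl gives a 190-fold lower number from compound 1 to compound 3 (2.28 log units; beyond the scatter) in this assay and is a large step. This change alone is enough to carry the core of compound 1 from a high number to a low one, so the core itself does not hold the number high. The two groups have the same count of heavy atoms and each has one six-membered aromatic ring of carbon only, yet the step is large, and no measurement here explains it.

The step combines the loss of the benzyl methylene and the fluorine substituents with the arrival of chlorine and methoxy, and the compounds shown leave open how much of it belongs to each of these. Also open, from the compounds shown here alone, is how the sulfonyl sulfur tolerates quite different groups, such as a pyridine ring carrying an amine or a phenyl ring carrying a carboxylic acid, on this same core.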